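This account rests on a few compounds, and the source may have more. Where it says the series, first, only, none or still open, it means among the compounds named here.

Measured so far:

Compound 1 `c1ccc(CN(CCCCN(C[C@H]2Cc3ccccc3CN2)[C@H]2CCCc3cccnc32)Cc2ccccn2)nc1` gives 664 nM in a functional assay on cells for antagonist activity at C-X-C chemokine receptor type 4 (Homo sapiens), read by fluorescence and calcium flux, with stated times of 25 min and 90 s; on this read-out lower numbers stand for stronger inhibition and higher numbers for weaker inhibition.
Compound 2 `c1ccc2c(c1)CN[C@@H](CN(CCCCN(Cc1ccncc1)Cc1ccncc1)[C@H]1CCCc3cccnc31)C2` gives 832 nM in this assay.
Compound 3 `c1ccc(CNCCCCN(C[C@H]2Cc3ccccc3CN2)[C@H]2CCCc3cccnc32)cc1` gives 20.1 nM in this assay.

Compound 3 has the lowest number of the three, and its gaps to compound 1 and to compound 2 are both beyond the usual scatter, so it is the most potent of the measured set. For the measured compounds named here, compound 1 and compound 2 carry two extra groups on one of the amine nitrogens, while compound 3 keeps that nitrogen with a single benzyl group; the data give no direct step that isolates this difference, so only the numbers themselves can be compared.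

Compound 4 `c1ccc2c(c1)CN[C@@H](CN(CCCCNC1CCOCC1)[C@H]1CCCc3cccnc31)C2` has not yet been measured. It differs from compound 3 in one place: oxan-4-yl in place of benzyl on an amine nitrogen. Going by the values given here, no measured pair in this set shows the same change, so its effect is not known from the data. The expectation is a modest loss of potency, with the step from compound 3 to compound 4 estimated at a 3.0-fold higher number from compound 3 to compound 4 (0.47 log units; beyond the scatter) in this assay. On that basis compound 4 is expected to give about 60 nM, within a range from 15 nM to 300 nM.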

Compound 4, half-maximal inhibitory concentration: 29.4 nM
Compound 4: middle estimate off by 2.0-fold (0.31 log units), on the high side; measured number inside the range.
By their numbers in this assay, from the lowest: compounds 3 and 4 (each within the scatter of the next); then compounds 1 and 2 (each within the scatter of the next).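

Putting oxan-4-yl in place of benzyl on this amine nitrogen gives a 1.5-fold higher number from compound 3 to compound 4 (0.17 log units; within the scatter) in this assay, so the two groups cannot be told apart in this read-out. For the compounds shown here, this is the first one-place step in the set, and it shows that this position does not depend on an aromatic ring of carbon only: a non-aromatic ring with one oxygen keeps the number within the scatter. No measured property of these groups is available to account for this result.

The compounds shown leave open how far this freedom extends, for example to an open-chain group such as isopropyl or to a piperidin-4-yl ring with nitrogen in place of the oxygen. They also leave open whether this nitrogen needs a ring at all, which a small methyl group would test.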